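The source may hold more compounds than are shown below. What is called first, only, known or untested is meant among the compounds shown, and "the series" means these compounds.

Three compounds have so far been measured in an ADME assay on L6 cells (Rattus norvegicus) for cytotoxicity, read by resazurin assay, with a stated time of 72 h; a lower number here means a stronger inhibitor, a higher number a weaker inhibitor:

compound 1, `NC1CC2(N3CCCC3)CC(c3ccccc3)C1C(c1ccccc1)C2`, with 38100 nM
compound 2, `O=C(CN1CCCCC1)OC1CC2(N3CCCC3)CC(c3ccccc3)C1C(c1ccccc1)C2`, with 14200 nM
compound 3, `CN(C)C12CC(N)C(C(c3ccccc3)C1)C(c1ccccc1)C2`, with 40900 nM

Compound 2 arises from compound 1 by one change, ((((piperidin-1-yl)methyl)carbonyl)oxy in place of amino on a saturated ring carbon). That change gave a 2.7-fold lower number from compound 1 to compound 2 (0.43 log units; beyond the scatter). Compound 3 and compound 1 differ in their cores, (dimethylamino in place of pyrrolidin-1-yl on a saturated ring carbon), and that difference gave a 1.1-fold higher number from compound 1 to compound 3 (0.03 log units; within the scatter), so these two values cannot be told apart.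

Compound 4, `CN(C)C12CC(OC(=O)CN3CCCCC3)C(C(c3ccccc3)C1)C(c1ccccc1)C2`, has not yet been measured in this assay. It arises from compound 3 by (((piperidin-1-yl)methyl)carbonyl)oxy in place of amino on a saturated ring carbon. The surroundings of the site are not identical: in compound 1 the site is two ring bonds from the ring atom that bears a pyrrolidin-1-yl group, in compound 3 it is two ring bonds from the ring atom that bears a dimethylamino group, so this is the same kind of change rather than the same change.

For the measured compounds named here, with only one measured instance to go on, the expected step is a 2.7-fold lower number from compound 3 to compound 4 (0.44 log units; beyond the scatter), placed beside the measured 2.7-fold lower number from compound 1 to compound 2 (0.43 log units; beyond the scatter). Compound 4 is therefore estimated at 15000 nM. For compound 4 the likely range runs from 7000 nM to 35000 nM.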

Compound 4, half-maximal inhibitory concentration: 29300 nM
Compound 4: middle estimate off by 2.0-fold (0.29 log units), on the low side; low and high end bracket the measured number.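

In this assay, putting (((piperidin-1-yl)methyl)carbonyl)oxy in place of amino on the core of compound 3 gave a 1.4-fold lower number from compound 3 to compound 4 (0.14 log units; within the scatter), and this does not differ measurably from the same change on the core of compound 1: the same change on two cores in this assay, a 2.7-fold lower number (0.43 log units; beyond the scatter) from compound 1 to compound 2 and a 1.4-fold lower number (0.14 log units; within the scatter) from compound 3 to compound 4, 1.9-fold (0.28 log units) apart, within the scatter of two such steps. Read the other way round, dimethylamino in place of pyrrolidin-1-yl gave a 2.1-fold higher number from compound 2 to compound 4 (0.31 log units; beyond the scatter) once the new group was present, and this also agrees with the earlier step: the same change on two cores in this assay, a 1.1-fold higher number (0.03 log units; within the scatter) from compound 1 to compound 3 and a 2.1-fold higher number (0.31 log units; beyond the scatter) from compound 2 to compound 4, 1.9-fold (0.28 log units) apart, within the scatter of two such steps. The change therefore carries over between these two cores as far as the scatter can tell, but a single pair of cores sets no general rule, and since only the step from compound 1 to compound 2 lies clearly beyond the scatter, a real drop on the core of compound 3 is not shown.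

Going by these compounds, it remains open how a morpholin-4-yl ring in place of the piperidin-1-yl ring, or a longer chain in place of the methyl link, would behave. The same holds for diethylamino on the ring atom that bears dimethylamino in compound 3.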